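Carboxylic acid to methylamide on two indole-type cores

The source may report more compounds than this note shows. Statements on the series, on what has been measured and on what is new or still open speak of the compounds shown alone.

Measured compounds:
compound 3 `O=C(O)/C=C/c1ccncc1-c1ccc2cc[nH]c2c1` gives 2.4 nM
compound 1 `CNC(=O)/C=C/c1ccncc1-c1ccc2cc[nH]c2c1` gives 18.6 nM
compound 2 `Cn1ncc2cc(-c3cnccc3/C=C/C(=O)O)ccc21` gives 34.6 nM

All three were tested in an assay on a protein complex for inhibition of CDK8/Cyclin C (Homo sapiens), with a stated time of 1 h; on this read-out higher numbers stand for weaker inhibition and lower numbers for stronger inhibition. Compound 3 carries the free acid and gives the lowest number of the three. Going by the values given here, compound 1 differs from it in one place, (methylamino in place of hydroxy on a carbonyl carbon), and the step of a 7.8-fold higher number from compound 3 to compound 1 (0.89 log units; beyond the scatter) is the only single change measured so far. Compound 2 carries the free acid on a second core; how the core of compound 2 differs from the core of compound 3 is not broken down here. Compound 2 and compound 1 give numbers that lie within the usual scatter of each other, so nothing can be said about their order.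

Compound 4 `CNC(=O)/C=C/c1ccncc1-c1ccc2c(cnn2C)c1` is not yet measured. It differs from compound 2 in one place, (methylamino in place of hydroxy on a carbonyl carbon), and the place is the same as for the pair of compound 3 and compound 1, so the change is the same. Among the compounds with values here, on that basis the step from compound 2 to compound 4 is expected to resemble the measured step, that is a 6.4-fold higher number from compound 2 to compound 4 (0.80 log units; beyond the scatter), resting on the single precedent a 7.8-fold higher number from compound 3 to compound 1 (0.89 log units; beyond the scatter) and without any check of how the second core carries the change. In this assay compound 4 is therefore estimated at 220 nM, with a range from 90 nM to 550 nM.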

Compound 4, half-maximal inhibitory concentration: 86.7 nM
The estimate for compound 4 lay 2.5-fold (0.40 log units) above the measured number, outside the stated range (below it).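

In this assay, methylamino in place of hydroxy on the carbonyl carbon gives a higher number on the second core as well, a 2.5-fold higher number from compound 2 to compound 4 (0.40 log units; beyond the scatter), so the direction of the change carries from one core to the other in these two pairs. Going by these compounds alone, the size of the step does not carry over, and the two steps differ clearly: the same change on two cores in this assay, a 7.8-fold higher number (0.89 log units; beyond the scatter) from compound 3 to compound 1 and a 2.5-fold higher number (0.40 log units; beyond the scatter) from compound 2 to compound 4, 3.1-fold (0.49 log units) apart, beyond the scatter of two such steps With only two pairs, this shows that the step from carboxy to methylcarbamoyl depends on the core, but it does not show which part of the core sets the size, nor what a third core would give.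

The compounds shown leave open how the two cores would respond to other groups on the carbonyl carbon, such as amino, ethylamino or dimethylamino, and whether the gap between the steps would persist with any of them. Also open is which single difference between the two cores goes with the smaller step, since the pairs shown change only the group on the carbonyl carbon and never one part of the core at a time.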